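The source may hold more compounds than are shown below. What is called first, only, known or untested is meant among the compounds shown, and "the series" means these compounds.

Three compounds have been measured so far:
compound 1 `COc1ccccc1OCC1SCCN1C(=O)CNC(C)=O`, giving 40 mg/kg
compound 2 `COC(=O)c1ccc(OCC2SCCN2C(=O)Cn2ccnc2)cc1`, giving 62 mg/kg
compound 3 `CCOC(=O)CC(=O)N1CC[S+]([O-])C1COc1ccccc1OC`, giving 27 mg/kg

All three numbers come from a functional assay on the whole organism for inhibition, with Cavia porcellus as the target; on this read-out lower numbers stand for an effect already at smaller amounts and higher numbers for an effect only at larger amounts of compound. Compound 1 stands second highest of the three; its number sits closest to that of compound 3, and the gap to compound 2 is the wider one, yet both gaps fall within the usual scatter of this assay, so none of the three can be set apart from the others on these data. The not yet measured compound 4 `COc1ccccc1OCC1SCCN1C(=O)C(C)(C)C(=O)O` keeps the core of compound 1 and differs from it in one place: 1-carboxy-1-methylethyl in place of acetamidomethyl on a carbonyl carbon. Among the measured compounds shown here, no measured pair of compounds shows this change, and the three measured compounds differ from one another in several places at once, so no step between measured compounds is available to lean on. The expected step is no change at the digits printed from compound 1 to compound 4 (within the scatter), which is no larger than the scatter in either direction. Compound 4 is estimated at 40 mg/kg in this assay, with a range from 15 mg/kg to 110 mg/kg.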

Compound 4, dose for half-maximal effect: 34 mg/kg
For compound 4 the middle estimate is 1.2-fold (0.07 log units) above the measured one, and the stated range covers the measured number.
By their numbers in this assay, from the lowest: compounds 3, 4, 1 and 2 (each within the scatter of the next, the first and the last beyond it).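

Among the compounds shown here, with the new step, the place on the carbonyl carbon whose other neighbour is the amide-type nitrogen in a ring can now be read directly for the first time: in this assay, 1-carboxy-1-methylethyl in place of acetamidomethyl gives a 1.2-fold lower number from compound 1 to compound 4 (0.07 log units; within the scatter), so the two compounds cannot be told apart. For the compounds shown here, on the core of compound 1, then, this exchange of one side chain for another, with a carboxylic acid in place of the acetamide, leaves no readable mark on the read-out, something the earlier compounds, which differ in several places at once, could not show. Nothing at hand offers an explanation for this result.

Going by these compounds, it remains open whether a side chain ending in an amine, or a longer alkyl chain, would also leave the number within the scatter at this place. Also open, on these data alone, is whether the carboxylic acid would behave the same way without the two methyl groups on the carbon that carries it.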